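The source may hold more compounds than are shown below. What is called first, only, known or untested is meant among the compounds shown, and "the series" means these compounds.

In an ADME assay on HepG2 2.2.15 cells (Homo sapiens) for cytotoxicity (a lower number here means that less compound is tolerated, a higher number that more compound is tolerated), compound 1 `Nc1c(-c2ccccc2Cl)c2cc(Cl)ccc2[nH]c1=O` gives 341000 nM. Compound 2 `O=c1[nH]c2ccc(Cl)cc2c(-c2ccccc2Cl)c1CCO` gives 1720000 nM in this assay, and the change from compound 1 to compound 2, 2-hydroxyethyl in place of amino on an aromatic carbon, brings a 5.0-fold higher number from compound 1 to compound 2 (0.70 log units; beyond the scatter). Compound 3 `O=c1cc(-c2ccccc2F)c2cc(Cl)ccc2[nH]1` reaches only a limit in this assay, > 5460000 nM, so its number is not known; (the limit of > 5460000 nM in this assay, at which 1 of the 3 values shown sits). Compound 4 `O=c1cc(-c2ccccc2Cl)c2cc(Cl)ccc2[nH]1` differs from compound 3 by chloro in place of fluoro on an aromatic carbon. Within the data shown here, none of the measured steps exchanges one halogen for another, so no measured step bears on this change, and no step beyond the scatter is expected in this assay. Compound 4 is therefore expected to sit around 5000000 nM, likely between 1500000 nM and 15000000 nM, which means an expected step of an at least 1.0-fold lower number from compound 3 to compound 4 (0.03 log units; that floor lies within the scatter).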

Compound 4, half-maximal cytotoxic concentration: 6000000 nM
The estimate for compound 4 lay 1.2-fold (0.08 log units) below the measured number; the range from low to high includes it.
By their numbers in this assay, from the lowest: compound 1; then compound 2; then compound 4.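

Earlier, only amino and 2-hydroxyethyl could be compared on this aromatic carbon of the shared core; hydrogen there now gives a reference point in this assay, with a 3.5-fold higher number from compound 2 to compound 4 (0.54 log units; beyond the scatter) and an 18-fold higher number from compound 1 to compound 4 (1.25 log units; beyond the scatter). Both groups thus go with less compound tolerated than hydrogen, amino the more so. The step from compound 3 cannot be read, as its value is only a limit: the limit of > 5460000 nM in this assay, at which 1 of the 4 values shown sits.

Going by these compounds, whether a carboxylic acid or a longer chain on that carbon would fit this order stays open. So does the size of any effect of chloro in place of fluoro.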